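A few compounds are considered here, and "the series" means these few. Any claim that something is new, unique, unknown or untested is made for them only; others in the source may bear on it.

Measured in a physicochemical assay for solubility, in phosphate buffer, with a stated time of 18 h, at pH 7.4; on this read-out higher numbers stand for higher solubility and lower numbers for lower solubility:
Compound 1 `COc1ccc2ncnc(-n3nc(-c4ccccn4)nc3N)c2c1` reads 7000 nM
Compound 2 `COc1cc2ncnc(-n3nc(N)nc3N)c2cc1OC` reads 83000 nM
Compound 3 `COc1cc2c(-n3nc(-c4ccccn4)nc3N)ncnc2cc1OCc1ccccc1` reads 68000 nM

The values of compound 3 and compound 2 lie within the usual scatter of each other, and both are well clear of compound 1. Compound 4 `COc1cc2c(-n3nc(-c4ccccn4)nc3N)ncnc2cc1O` has not yet been measured. It differs from compound 3 by hydrogen in place of benzyl on an oxygen on an aromatic ring (hydrogen in place of benzyl on an oxygen on an aromatic ring, or benzyloxy to hydroxy). For the measured compounds named here, only one measured step bears on this change, a modest one with benzyloxy in place of hydrogen on an aromatic carbon. Going by the values given here, with that step, a 9.7-fold higher number from compound 1 to compound 3 (0.99 log units; beyond the scatter), as the sole guide, a lower number is expected in this assay on removing the benzyl. Compound 4 keeps the oxygen that compound 1 lacks, so only part of that step is expected to be undone. The expected change is a 2.7-fold lower number from compound 3 to compound 4 (0.43 log units; beyond the scatter) as estimated here. For compound 4 the estimate is 25000 nM with an expected range from 6000 nM to 90000 nM in this read-out.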

Compound 4, solubility: 44000 nM
The estimate for compound 4 lay 1.8-fold (0.25 log units) below the measured number, and the stated range covers the measured number.
By their numbers in this assay, from the lowest: compound 1; then compounds 4, 3 and 2 (each within the scatter of the next).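

In this assay, taking the benzyl off the oxygen gives a 1.5-fold lower number from compound 3 to compound 4 (0.19 log units; within the scatter) and stays within the scatter, so the benzyl ring itself makes no readable difference at this position. The hydroxy alone gives a 6.3-fold higher number from compound 1 to compound 4 (0.80 log units; beyond the scatter) and lies beyond the scatter, so compound 4 stands apart from compound 1 much as compound 3 does, and that separation no longer depends on the benzyl. No measurement shown here accounts for this.

Open, on these data alone, is whether a longer chain on this oxygen, or one ending in an amine or a carboxylic acid, would read with compound 3 and compound 4 or fall back toward compound 1. As far as these compounds go, whether the hydroxy step holds on another core also remains open, as it rests on this single pair.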